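A Nitro Group Tried on Two Different Cores

The compounds below may be only part of what the source reports. "The series", "measured", "known", "first", "only" and "open" are said of these compounds alone.

Compound 1, `COC(=O)C1=C(C)N=C(SC)NC1c1ccccc1SC`: 1520 nM
Compound 2, `COC(=O)C1=C(C)N=C(SC)NC1c1cc([N+](=O)[O-])ccc1SC`: 2700 nM
Compound 3, `CSC1=NC2/C(=C(/O)OCCCCCSc3ccccc32)C(C)=N1`: 18 nM

Of the compounds shown here, three have been measured in an assay on Myocardium (Cavia porcellus) for displacement of a labelled ligand from Voltage-dependent L-type calcium channel subunit alpha-1C (Homo sapiens); a higher number here means weaker binding, a lower number tighter binding. Compound 1 has the structure `COC(=O)C1=C(C)N=C(SC)NC1c1ccccc1SC` and gives 1520 nM in this assay. Compound 2, `COC(=O)C1=C(C)N=C(SC)NC1c1cc([N+](=O)[O-])ccc1SC`, differs from it in one place: nitro in place of hydrogen on an aromatic carbon. That change made a 1.8-fold higher number from compound 1 to compound 2 (0.25 log units; within the scatter).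

Compound 3, `CSC1=NC2/C(=C(/O)OCCCCCSc3ccccc32)C(C)=N1`, is built on a different core; how it differs from compound 1 is not broken down here. In this assay compound 3 gives 18 nM, the lowest of the three numbers, and its gap to compound 1 and to compound 2 is beyond the scatter.

Compound 4, `CSC1=NC2/C(=C(/O)OCCCCCSc3c2cccc3[N+](=O)[O-])C(C)=N1`, has not yet been measured. It differs from compound 3 by nitro in place of hydrogen on an aromatic carbon. Among the compounds with values here, this is the same kind of change as the one from compound 1 to compound 2, but not the same: there the nitro group entered meta to a large group and para to a methylsulfanyl group, whereas here it enters ortho to a fused ring and meta to a fused ring, within a fused or bridged system of three rings.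

Because the earlier step was a 1.8-fold higher number from compound 1 to compound 2 (0.25 log units; within the scatter), a step of similar size is expected here, giving a 1.7-fold higher number from compound 3 to compound 4 (0.22 log units; within the scatter), with extra room for the different surroundings. For compound 4 the expected value in this assay is 30 nM, likely between 10 nM and 100 nM.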

Compound 4, dissociation constant: 5 nM
Estimate against measurement, compound 4: 6.0-fold (0.78 log units) above; measured number below the stated range.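

In this assay, putting nitro in place of hydrogen on an aromatic carbon gave a 3.6-fold lower number from compound 3 to compound 4 (0.56 log units; beyond the scatter), a step beyond the scatter, whereas the earlier step with this change, on the other core, stayed within the scatter. Set side by side, the two steps differ, so in this series the result of the change on one core could not simply be carried over to the other: the same change on two cores in this assay, a 1.8-fold higher number (0.25 log units; within the scatter) from compound 1 to compound 2 and a 3.6-fold lower number (0.56 log units; beyond the scatter) from compound 3 to compound 4, 6.4-fold (0.81 log units) apart, beyond the scatter of two such steps. This rests on a single pair of compounds per core, and the nitro group sits in different surroundings in each pair, so it does not show whether the core itself, the place on the ring, or both account for the gap, and it says nothing about how any other group would behave.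

The compounds shown leave open whether an amine or a nitrile at the same place on the aromatic ring of compound 3 would give a similar step, and whether nitro on another carbon of that ring would do the same. Within the data shown here, also open is whether a longer chain in place of the one in compound 4 would keep the number this low.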